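Swapping an aryl ether for a trifluoromethylphenyl group

The source may report more compounds than this note shows. Statements on the series, on what has been measured and on what is new or still open speak of the compounds shown alone.

Among the three measured compounds, compound 3 `COc1ccccc1Oc1ccc2c(NCCCNCc3cccc(OC)c3O)ccnc2c1` stands highest in an ADME assay for permeability, using PAMPA, with a stated time of 30 min, at pH 7.4; on this read-out higher numbers stand for higher permeability and lower numbers for lower permeability: compound 3 gives 317 10^-6 cm/s. Compound 2 `COc1cccc(CNCCCNc2ccnc3cc(-c4ccccc4)ccc23)c1O` gives 237 10^-6 cm/s, and compound 1 `COc1cccc(CNCCCNc2ccnc3cc(Cc4ccc(C#N)cc4)ccc23)c1O` gives 23 10^-6 cm/s. The step of a 1.3-fold higher number from compound 2 to compound 3 (0.13 log units; within the scatter) stays within the scatter, whereas the steps of a 10-fold higher number from compound 1 to compound 2 (1.01 log units; beyond the scatter) and a 14-fold higher number from compound 1 to compound 3 (1.14 log units; beyond the scatter) are large. Compound 4 `COc1cccc(CNCCCNc2ccnc3cc(-c4ccc(C(F)(F)F)cc4)ccc23)c1O` differs from compound 3 by 4-(trifluoromethyl)phenyl in place of 2-methoxyphenoxy on an aromatic carbon, that is, 4-(trifluoromethyl)phenyl in place of 2-methoxyphenoxy. The nearest guide is compound 2, which carries a plain phenyl at the same place and gives 237 10^-6 cm/s in this assay. Compound 4 is therefore expected to land near that level, at 200 10^-6 cm/s with a range of 60 10^-6 cm/s to 500 10^-6 cm/s. The expected step of a 1.6-fold lower number from compound 3 to compound 4 (0.20 log units; within the scatter) should remain within the scatter.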

Compound 4, apparent permeability: 237 10^-6 cm/s
Compound 4: middle estimate off by 1.2-fold (0.07 log units), on the low side; low and high end bracket the measured number.
By their numbers in this assay, from the lowest: compound 1; then compounds 2, 4 and 3 (each within the scatter of the next).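

In this assay, trifluoromethyl on the phenyl ring makes no visible difference (no change at the digits printed from compound 2 to compound 4 (within the scatter)), and replacing 2-methoxyphenoxy with 4-(trifluoromethyl)phenyl also stays within the scatter (a 1.3-fold lower number from compound 3 to compound 4 (0.13 log units; within the scatter)). Compound 1, with its 4-cyanobenzyl group, remains the only clear outlier among these compounds, and compound 4 shows the same wide gap to it (a 10-fold higher number from compound 1 to compound 4 (1.01 log units; beyond the scatter)). Nothing available explains these numbers. Going by these compounds, it remains open whether an amine or a carboxylic acid at this place would fit the higher group, and whether plain benzyl would sit near compound 1.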